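The source may hold more compounds than are shown below. What is called first, only, known or untested is meant among the compounds shown, and "the series" means these compounds.

Of the compounds shown here, three have so far been measured in a physicochemical assay for lipophilicity, in phosphate buffer, measured as octanol-water partition; on this read-out lower numbers stand for lower lipophilicity and higher numbers for higher lipophilicity. Compound 1 `Cc1nc2ccccc2c(=O)n1/N=C/c1ccc(Oc2ccccc2)cc1` gives 4.01 in this assay. Compound 2 `Cc1nc2ccccc2c(=O)n1/N=C/c1ccc(Oc2ccc([N+](=O)[O-])cc2)cc1` gives 4.01. Compound 3 `CCCc1nc2ccccc2c(=O)n1/N=C/c1ccc(Oc2ccc([N+](=O)[O-])cc2)cc1` gives 5.18, the highest of the three numbers, with both other compounds lying beyond the scatter below it. The step of no change at the digits printed from compound 2 to compound 1 (within the scatter) belongs to the change (hydrogen in place of nitro on an aromatic carbon). The step of a number 1.17 log units higher from compound 2 to compound 3 (beyond the scatter) belongs to the change (ethyl in place of hydrogen on a saturated chain carbon bound to an aromatic carbon), which is also how the core of compound 3 differs from the core of compound 2.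

Compound 4 `CCCc1nc2ccccc2c(=O)n1/N=C/c1ccc(Oc2ccccc2)cc1` has not yet been measured in this assay. It differs from compound 3 by hydrogen in place of nitro on an aromatic carbon, the same change as that from compound 2 to compound 1, so that this change occurs twice among the four compounds. Because no change at the digits printed from compound 2 to compound 1 (within the scatter) stayed within the scatter, the step expected for compound 4 is a number 0.02 log units higher from compound 3 to compound 4 (within the scatter) in this assay. The estimate for compound 4 is 5.2, expected to fall between 4.8 and 5.6.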

Compound 4, partition coefficient: 5.2
Compound 4: middle estimate and measured number agree at the digits printed, within the range that was stated.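

In this assay, hydrogen in place of nitro gave no change at the digits printed from compound 2 to compound 1 (within the scatter) on the first core and a number 0.02 log units higher from compound 3 to compound 4 (within the scatter) on the second, so this change stayed within the scatter on both cores shown. Ethyl in place of hydrogen on the saturated chain carbon also carried across, giving a number 1.17 log units higher from compound 2 to compound 3 (beyond the scatter) with nitro on the ring and a number 1.19 log units higher from compound 1 to compound 4 (beyond the scatter) with hydrogen there, and both of these steps are large. This shows agreement across these four compounds only, not a rule for other cores, and nothing measured here gives a reason for either result.

From the compounds shown here alone, whether other groups at that place on the ring, such as an amine or a carboxylic acid, would also leave the number within the scatter remains open. Among the compounds shown here, it is also open how the number would move with a longer chain than the one shared by compound 3 and compound 4.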